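The compounds below may be only part of what the source reports. "The series", "measured", "known", "first", "only" and "open" are said of these compounds alone.

Of the compounds shown here, two built on one shared core have been tested in a functional assay on MGC-803 cells (Homo sapiens) for antiproliferative activity, read by MTT assay, with a stated time of 72 h; a higher number here means a weaker inhibitor, a lower number a stronger inhibitor. Compound 1, `C/C(=N\NC(=O)c1cccc(S(=O)(=O)N2CCOCC2)c1)c1cccc(N)c1`, gives in this assay only a limit, > 100000 nM. That limit is the one described as the limit of > 100000 nM in this assay, at which 1 of the 2 values shown sits. Compound 2, `C/C(=N\NC(=O)c1cccc(S(=O)(=O)N2CCOCC2)c1)c1ccc(O)cc1`, gives in this assay a number, 71400 nM. For the measured compounds named here, the single measured step, an at least 1.4-fold lower number from compound 1 to compound 2 (0.14 log units; that floor lies within the scatter), is bounded by that limit, and its floor lies within the scatter of repeated measurements, so it shows little about how a change on this ring moves the numbers. Going by the values given here, compound 2 thus stands as the only compound with a number in this assay, the other value being a limit.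

Compound 3, `C/C(=N\NC(=O)c1cccc(S(=O)(=O)N2CCOCC2)c1)c1cc(O)ccc1O`, differs from compound 2 by 2,5-dihydroxyphenyl in place of 4-hydroxyphenyl on a carbon with a double bond to nitrogen. The step from compound 1 to compound 2 is the only one that bears on this change, since it also alters the group on a carbon with a double bond to nitrogen, and its size is not resolved beyond a floor within the scatter. No basis therefore exists for expecting a step beyond the scatter in this assay, in either direction. The step this estimate means is a 1.2-fold lower number from compound 2 to compound 3 (0.08 log units; within the scatter). Compound 3 is expected at 60000 nM in this assay, with a range from 20000 nM to 150000 nM.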

Compound 3, half-maximal inhibitory concentration: 9090 nM
The estimate for compound 3 lay 6.6-fold (0.82 log units) above the measured number; the measured number lies below the stated range.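

Swapping 4-hydroxyphenyl for 2,5-dihydroxyphenyl on the carbon with a double bond to nitrogen gives a 7.9-fold lower number from compound 2 to compound 3 (0.90 log units; beyond the scatter) in this assay. For the compounds shown here, this is the first step that stands clear of the scatter, so the numbers at this position do respond to the group it carries. Replacing 3-aminophenyl with the same 2,5-dihydroxyphenyl group gives an at least 11-fold lower number from compound 1 to compound 3 (1.04 log units; beyond the scatter), but the full size of that step stays unknown because compound 1 gives a limit and not a number: the limit of > 100000 nM in this assay, at which 1 of the 3 values shown sits.

The step from compound 2 to compound 3 adds a hydroxyl group, but the compounds shown cannot tell whether both hydroxyl groups of the 2,5-dihydroxyphenyl ring are needed for the lower number or only one of them. On these data alone, it also remains open how the number would move if a methoxy group or a fluorine atom stood in place of either hydroxyl group, and whether the same gain would appear if the shared core were changed elsewhere.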